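A few compounds are considered here, and "the series" means these few. Any claim that something is new, unique, unknown or untested is made for them only; others in the source may bear on it.

Compound 1 `O=C1O[C@H]([C@@H](O)Cn2cc(-c3cccc(O)c3)nn2)C(OCc2ccccc2)=C1OCc1ccccc1` gives 39300 nM in a functional assay on HeLa cells (Homo sapiens) for antiproliferative activity, read by MTT assay, with a stated time of 72 h; a higher number here means a weaker inhibitor, a lower number a stronger inhibitor. Compound 2 `O=C1O[C@H]([C@@H](O)Cn2cc(-c3cc(F)cc(F)c3)nn2)C(OCc2ccccc2)=C1OCc1ccccc1` gives 40800 nM. Compound 3 `Cc1ccc(-c2cn(C/C=C3\OC(=O)C(OCc4ccccc4)=C3OCc3ccccc3)nn2)cc1` gives 7480 nM.

Compound 2 holds the highest of these three numbers; compound 1 sits within the scatter of it, while compound 3 gives a lower number, beyond the scatter. Within the data shown here, compound 4 `O=C1O[C@H]([C@@H](O)Cn2cc(CNS(=O)(=O)c3ccc(F)cc3)nn2)C(OCc2ccccc2)=C1OCc1ccccc1` has not been measured. (((4-fluorophenyl)sulfonyl)amino)methyl in place of 3,5-difluorophenyl on an aromatic carbon The only measured step that also exchanges the group on that aromatic carbon, a 1.0-fold higher number from compound 1 to compound 2 (0.02 log units; within the scatter), stayed within the scatter, but it swapped one aromatic ring for another, whereas here a group carrying a sulfonyl and a hydrogen-bond donor enters. Among the measured compounds shown here, with no step of that kind measured, no change beyond the scatter is expected. Compound 4 is therefore estimated at 45000 nM, between 15000 nM and 120000 nM, which would be an expected 1.1-fold higher number from compound 2 to compound 4 (0.04 log units; within the scatter).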

Compound 4, half-maximal inhibitory concentration: 25000 nM
Estimate against measurement, compound 4: 1.8-fold (0.26 log units) above, within the range that was stated.
By their numbers in this assay, from the lowest: compound 3; then compounds 4, 1 and 2 (each within the scatter of the next).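

Both a 1.6-fold lower number from compound 2 to compound 4 (0.21 log units; within the scatter) and a 1.6-fold lower number from compound 1 to compound 4 (0.20 log units; within the scatter) stay within the scatter in this assay, so this aromatic carbon tolerates more than the exchange of one directly attached aromatic ring for another. The larger (((4-fluorophenyl)sulfonyl)amino)methyl group, which brings a hydrogen-bond donor and hydrogen-bond acceptors, leaves compound 4 indistinguishable from compound 1 and compound 2. No measurement shown here offers an explanation for this result. From the compounds shown here alone, whether a simple amine, a carboxylic acid or a longer alkyl chain at this position would move the number beyond the scatter remains open.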